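Azetidin-3-yl in Place of tert-Butyl: Cytotoxicity Outlook

The source may hold more compounds than are shown below. What is called first, only, known or untested is meant among the compounds shown, and "the series" means these compounds.

Measured so far in an ADME assay on HeLa cells (Homo sapiens) for cytotoxicity, read by ATP content, with a stated time of 3 days; on this read-out lower numbers stand for higher toxicity in this test and higher numbers for lower toxicity in this test:
- compound 1 `CC(C)(C)n1c(=O)n(Cc2cc3cc(Cl)ccc3n2CCCS(C)(=O)=O)c2cnccc21` gives > 50000 nM
- compound 2 `N#CCCCn1c(Cn2c(=O)n(C3CC3)c3ccncc32)nc2nc(Cl)ccc21` gives > 50000 nM
- compound 3 `COc1ccc(-n2c(=O)n(Cc3cc4cc(Cl)ccc4n3CCCC#N)c3cnccc32)cc1C` gives > 50000 nM

Each of these values is a limit of this assay, not a number: the test ran up to its highest concentration without reaching a half-maximal effect. For compound 1 that means only a boundary is known, not where its true value lies. Compound 2 and compound 3, each built on a related core with a chloro-bearing bicyclic ring, end at the same boundary. Among the compounds with values here, all three results therefore sit together at the limit of > 50000 nM in this assay, at which 3 of the 3 values shown sit, and no two of the measured compounds differ in just one place, so no single structural step has yet been measured.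

Compound 4 `CS(=O)(=O)CCCn1c(Cn2c(=O)n(C3CNC3)c3ccncc32)cc2cc(Cl)ccc21` is the compound still to be tested. Relative to compound 1 its change is azetidin-3-yl in place of tert-butyl on an aromatic nitrogen. Within the data shown here, with every measured neighbour parked at the assay boundary, there is no measured step to lean on. The step from compound 1 to compound 4 a step that the limit leaves unreadable from compound 1 to compound 4 is expected to show nothing beyond the usual scatter, with a good chance that the assay again reports only a limit. Compound 4 is therefore estimated at 60000 nM, with a range from 20000 nM to 200000 nM.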

Compound 4, half-maximal cytotoxic concentration: > 50000 nM
Compound 4 was reported as a limit (the forecaster's own chance of this, stated with the estimate: 80%); the middle value lies beyond the limit too.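

The results for compound 1 and compound 4 are both limits, not numbers, so the change from tert-butyl to azetidin-3-yl cannot be read as a step in this assay, where all results shown share one boundary: the limit of > 50000 nM in this assay, at which 4 of the 4 values shown sit.

In this assay, the compounds shown leave open where each true half-maximal cytotoxic concentration lies and whether any structural change alters it.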